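Alkyl homologues on a shared core: working notes

The source may report more compounds than this note shows. Statements on the series, on what has been measured and on what is new or still open speak of the compounds shown alone.

Measured so far in a functional assay on L1210 cells (Mus musculus); a lower number here means a stronger inhibitor, a higher number a weaker inhibitor:
- compound 1, `CCc1cn([C@H]2C[C@@H]3OP(=O)(O)OC[C@H]3O2)c(=O)[nH]c1=O`; compound 1 gives > 500 ug/mL, a limit of the assay and not a number.
- compound 2, `CCCCc1cn([C@H]2C[C@H](O)[C@@H](CO)O2)c(=O)[nH]c1=O`; compound 2 gives > 500 ug/mL, likewise a limit.
- compound 3, `CC(C)c1cn([C@H]2C[C@@H]3OP(=O)(O)OC[C@H]3O2)c(=O)[nH]c1=O`; compound 3 gives > 500 ug/mL, again a limit.

Compound 3 differs from compound 1 by methyl in place of hydrogen on a saturated chain carbon bound to an aromatic carbon and a saturated chain carbon. In this assay the step is a step that the two limits leave unreadable from compound 1 to compound 3, because all three values sit at the limit of > 500 ug/mL in this assay, at which 3 of the 3 values shown sit. Compound 2 and compound 1 have different cores; that difference is not broken down here.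

Compound 4, `CCCCCc1cn([C@H]2C[C@H](O)[C@@H](CO)O2)c(=O)[nH]c1=O`, is not yet measured and differs from compound 2 by methyl in place of hydrogen on a saturated chain carbon, four bonds along the chain from an aromatic carbon. This is the same kind of change as from compound 1 to compound 3, but at a different place: there on a saturated chain carbon bound to an aromatic carbon and a saturated chain carbon, here on a saturated chain carbon four bonds along the chain from an aromatic carbon. The expected step in this assay is a number no higher from compound 2 to compound 4 (the limit leaves the size open), resting on (the limit of > 500 ug/mL in this assay, at which 3 of the 3 values shown sit). Compound 4 is estimated at 500 ug/mL, between 150 ug/mL and 1500 ug/mL, most probably reported only as a limit.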

Compound 4, concentration for 50% inhibition: 477 ug/mL
Compound 4: the middle estimate sits 1.0-fold (0.02 log units) above what was measured; measured number inside the range.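

In this assay compound 2 gives > 500 ug/mL, a limit and not a number. On these data alone, the step reads as an at least 1.0-fold lower number from compound 2 to compound 4 (0.02 log units; that floor lies within the scatter), so methyl in place of hydrogen shows no shift beyond the scatter on this core, though the true size stays open. The same kind of change on the core of compound 1 sits at a different place and cannot be read, so no transfer between the two cores is shown, because nearly all values stop at the limit: the limit of > 500 ug/mL in this assay, at which 3 of the 4 values shown sit.

Open, as far as these compounds go, is how a chain longer than that of compound 4 reads on this core in this assay. Also open, from the compounds shown here alone, is how an amine or a carboxylic acid in place of the methyl would read.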